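A few compounds are considered here, and "the series" means these few. Any claim that something is new, unique, unknown or untested is made for them only; others in the source may bear on it.

Compound 1 `C=CCn1c(=O)/c(=C\c2ccc(F)c(Br)c2)[nH]c(=O)/c1=C\c1ccccc1OC` — "not active" (no number reported)
Compound 2 `COc1ccccc1/C=c1/[nH]c(=O)/c(=C\c2nc[nH]c2C(C)(C)C)[nH]c1=O` — 60 nM
Compound 3 `COc1ccccc1/C=c1/[nH]c(=O)/c(=C\c2cccc(Cl)c2Cl)[nH]c1=O` — "not active" (no number reported)

The three measured compounds share one core and were tested in a functional assay on K562 cells (Homo sapiens) for cytotoxicity, read by CCK-8 assay, with a stated time of 72 h; on this read-out higher numbers stand for weaker inhibition and lower numbers for stronger inhibition. Compound 1 was reported as "not active" (no number reported), with no half-maximal inhibitory concentration given. Compound 3 also returned "not active" (no number reported) in this assay, so compound 1 stands alongside one further compound for which no single number exists. Going by the values given here, only compound 2 carries a number, giving 60 nM in this assay; no step links it to compound 1, so the pair shows only that one member is numbered and the other is not.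

Compound 4 `C=CCn1c(=O)/c(=C\c2ccc(Cl)c(Cl)c2)[nH]c(=O)/c1=C\c1ccccc1OC` has not been measured. It differs from compound 1 in one place: 3,4-dichlorophenyl in place of 3-bromo-4-fluorophenyl on a double-bonded chain carbon bound to an aromatic carbon. Among the compounds with values here, no step between measured compounds describes such a change, so the size of the step from compound 1 to compound 4 in this assay cannot be read from the data. Since compound 1 has no number, the expectation for compound 4 rests mainly on that outcome, and a report without a number is held to be the likelier result.

Compound 4 is therefore estimated at 20000 nM in this assay, with an expected range from 4000 nM to 100000 nM.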

Compound 4, half-maximal inhibitory concentration: "not active" (no number reported)
For compound 4 the study gives words and no number; the estimate stays without a comparison.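

In this assay, compound 1 gives "not active" (no number reported) and compound 4 gives "not active" (no number reported), so no new step can be read from this pair. The compounds shown leave open how large any effect of exchanging 3-bromo-4-fluorophenyl for 3,4-dichlorophenyl might be. No available evidence bears on this result.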